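This account rests on a few compounds, and the source may have more. Where it says the series, first, only, none or still open, it means among the compounds named here.

Compound 1 `C=C(Br)C(=O)Nc1cccc(/C=C/C(=O)Nc2ccc(F)cc2)c1`: 6200 nM
Compound 2 `C=C(Br)C(=O)Nc1cccc(/C=C/C(=O)Nc2ccc(F)c(F)c2)c1`: 550 nM

In a functional assay on Jurkat cells (Homo sapiens) for inhibition, read by MTT assay, with a stated time of 72 h (on this read-out lower numbers stand for stronger inhibition and higher numbers for weaker inhibition), compound 1 holds the higher of the two numbers, at 6200 nM. Compound 3 `C=C(Br)C(=O)Nc1cccc(/C=C/C(=O)Nc2ccc(OC(F)(F)F)cc2)c1` departs from it by trifluoromethoxy in place of fluoro on an aromatic carbon, para to a large group. Among the measured compounds shown here, only one measured step bears on this change, and only indirectly. That step, an 11-fold lower number from compound 1 to compound 2 (1.05 log units; beyond the scatter), is large and comes from fluoro in place of hydrogen on an aromatic carbon. For the measured compounds named here, it shows that a small substitution can move the number in this assay strongly, but it is a different change, and no measured compound carries trifluoromethoxy. A lower number is therefore expected, by less than that step, and with wide uncertainty. The estimated step is a 3.4-fold lower number from compound 1 to compound 3 (0.54 log units; beyond the scatter). For compound 3, the expected value is 1800 nM, with an estimated range of 500 nM to 6500 nM.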

Compound 3, half-maximal inhibitory concentration: 30300 nM
For compound 3 the middle estimate is 17-fold (1.23 log units) below the measured one, outside the stated range (above it).
By their numbers in this assay, from the lowest: compound 2; then compound 1; then compound 3.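

In this assay, trifluoromethoxy in place of fluoro on an aromatic carbon, para to a large group, gives a 4.9-fold higher number from compound 1 to compound 3 (0.69 log units; beyond the scatter), so this position does not accept every substituent without loss. The direction is opposite to that of the earlier step, an 11-fold lower number from compound 1 to compound 2 (1.05 log units; beyond the scatter), which left this fluoro in place and added a second one; substitution on this ring can therefore move the number either way, depending on the change. Nothing measured here explains the rise in the number for compound 3.

From the compounds shown here alone, with a single replacement at this position, it remains open whether the rise follows from the size of the group or from something specific to trifluoromethoxy. Chloro, methoxy or trifluoromethyl at the same carbon would help separate these readings.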